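Dimethylaminomethyl series: dichlorophenyl in place of fluorophenyl

A few compounds are considered here, and "the series" means these few. Any claim that something is new, unique, unknown or untested is made for them only; others in the source may bear on it.

Compound 2 `CN(C)CC1CCC/C(=C\c2ccc(OC(=O)/C=C/c3ccc(F)cc3)cc2)C1=O` holds the lower of the two numbers in a functional assay on CCRF-CEM cells (Homo sapiens) (a higher number here means a weaker inhibitor, a lower number a stronger inhibitor), where compound 2 gives 6000 nM. For the measured compounds named here, compound 1 `O=C(/C=C/c1ccc(Cl)c(Cl)c1)Oc1ccc(/C=C2\CCCCC2=O)cc1` gives 63800 nM in this assay, a higher number beyond the scatter; the two structures differ in more than one place, so no single step is read from them. Compound 3 `CN(C)CC1CCC/C(=C\c2ccc(OC(=O)/C=C/c3ccc(Cl)c(Cl)c3)cc2)C1=O` differs from compound 2 as follows: 3,4-dichlorophenyl in place of 4-fluorophenyl on a double-bonded chain carbon bound to a double-bonded chain carbon. Going by the values given here, no measured pair isolates this change. For compound 3 a step of a 1.3-fold higher number from compound 2 to compound 3 (0.12 log units; within the scatter) is expected, slightly weaker, near the scatter. Compound 3 is estimated at 8000 nM, between 2500 nM and 25000 nM.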

Compound 3, half-maximal inhibitory concentration: 5820 nM
The estimate for compound 3 lay 1.4-fold (0.14 log units) above the measured number; measured number inside the range.
By their numbers in this assay, from the lowest: compounds 3 and 2 (each within the scatter of the next); then compound 1.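

In this assay, 3,4-dichlorophenyl in place of 4-fluorophenyl on a double-bonded chain carbon gives a 1.0-fold lower number from compound 2 to compound 3 (0.01 log units; within the scatter) and so leaves no readable difference between these two groups at this position. With 3,4-dichlorophenyl held fixed, (dimethylamino)methyl in place of hydrogen on a saturated ring carbon gives an 11-fold lower number from compound 1 to compound 3 (1.04 log units; beyond the scatter) and is now read as a single change. Nothing at hand accounts for either step.

Open, as far as these compounds go, is whether a morpholine or piperidine in place of the dimethylamino group would hold this number. Also open, from the compounds shown here alone, is how an unsubstituted phenyl or 4-methoxyphenyl would read on this chain.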